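Methoxy addition on a shared core: growth inhibition notes

The compounds below may be only part of what the source reports. "The series", "measured", "known", "first", "only" and "open" are said of these compounds alone.

Measured so far:
Compound 1 `COc1ccc(Cn2cc(CNC(=O)c3cn(-c4ccccc4)nc3-c3ccc(F)cc3)nn2)cc1` — in a functional assay on MIA PaCa-2 cells (Homo sapiens) for antiproliferative activity, read by sulforhodamine B assay, with a stated time of 48 h (on this read-out higher numbers stand for weaker inhibition of growth and lower numbers for stronger inhibition of growth), compound 1 gives 3700 nM.
Compound 2 `COc1ccc(Cn2cc(CNC(=O)c3cn(-c4ccccc4)nc3-c3ccc(F)cc3)nn2)cc1OC` — in this assay compound 2 reaches only a limit of the assay, > 100000 nM.
Compound 3 `COc1ccc(Cn2cc(CNC(=O)c3cn(-c4ccccc4)nc3-c3ccc(Cl)cc3)nn2)cc1` — in this assay compound 3 gives 290 nM.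

Compound 1 and compound 3 differ in the core by chloro in place of fluoro on an aromatic carbon. The step is a 13-fold lower number from compound 1 to compound 3 (1.11 log units; beyond the scatter), which leaves compound 3 with the lowest of the two numbers recorded. Compound 1 and compound 2 differ by methoxy in place of hydrogen on an aromatic carbon. The step is an at least 27-fold higher number from compound 1 to compound 2 (1.43 log units; beyond the scatter); its true size is not known because compound 2 sits at the limit of > 100000 nM in this assay, at which 1 of the 3 values shown sits.

Compound 4 `COc1ccc(Cn2cc(CNC(=O)c3cn(-c4ccccc4)nc3-c3ccc(Cl)cc3)nn2)cc1OC` is not yet measured. It differs from compound 3 by methoxy in place of hydrogen on an aromatic carbon, the same change as that from compound 1 to compound 2, and the two cores differ by chloro in place of fluoro on an aromatic carbon. The change has been made once before, and that single occurrence gave a large loss that ran into the assay limit. Starting from the lower number of compound 3, the same loss would still leave a number inside the measurable range, though a limit cannot be ruled out.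

The expected step of a 52-fold higher number from compound 3 to compound 4 (1.71 log units; beyond the scatter) rests on an at least 27-fold higher number from compound 1 to compound 2 (1.43 log units; beyond the scatter) and on the value of compound 2 being only a limit. Compound 4 is therefore expected at about 15000 nM, most likely between 3000 nM and 100000 nM.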

Compound 4, concentration for 50% growth inhibition: 9400 nM
The estimate for compound 4 lay 1.6-fold (0.20 log units) above the measured number, and the stated range covers the measured number.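

Going from 4-methoxybenzyl to 3,4-dimethoxybenzyl on the core of compound 3 gives a 32-fold higher number from compound 3 to compound 4 (1.51 log units; beyond the scatter) in this assay, so the loss seen on the core of compound 1 appears on this second core too, and the two steps compare as follows: the same change on two cores in this assay, an at least 27-fold higher number (1.43 log units; beyond the scatter) from compound 1 to compound 2 and a 32-fold higher number (1.51 log units; beyond the scatter) from compound 3 to compound 4; the limit leaves it open whether they differ
The chloro in place of fluoro change also holds its direction in the dimethoxy pair, with an at least 10-fold lower number from compound 2 to compound 4 (1.02 log units; beyond the scatter), and it sets beside the earlier step as follows: the same change on two cores in this assay, a 13-fold lower number (1.11 log units; beyond the scatter) from compound 1 to compound 3 and an at least 10-fold lower number (1.02 log units; beyond the scatter) from compound 2 to compound 4; the limit leaves it open whether they differ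
From the compounds shown here alone, compound 2 stands at a limit of the assay, > 100000 nM, so the size of the methoxy step on the core of compound 1 stays unknown, and these two pairs show that the direction carried over between two cores but not that the size did, nor that it would carry to any further core.

Open, going by these compounds, is whether the loss belongs to methoxy itself or would follow from other groups on the same aromatic carbon, such as hydroxy, fluoro or the longer ethoxy chain. Also open, on these data alone, is whether the methoxy step keeps its direction when bromo or methyl takes the place of chloro on the core.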